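Replacing phenyl with thiophen-2-yl in compound 1

A few compounds are considered here, and "the series" means these few. Any claim that something is new, unique, unknown or untested is made for them only; others in the source may bear on it.

Compound 1 `COc1cc(/C=C/C(=O)/C=C/c2ccccc2)ccc1OCc1cn(CCCCOc2cc(=O)oc3ccccc23)nn1`: 34%
Compound 2 `COc1cc(/C=C/C(=O)/C=C/c2cccs2)ccc1OCc1cn(CCCCCOc2cc(=O)oc3ccccc23)nn1`: 31%
Compound 3 `COc1ccccc1/C=C/C(=O)/C=C/c1ccc(OCc2cn(CCCCCOc3cc(=O)oc4ccccc34)nn2)c(OC)c1`: 33%

In a functional assay on HCT-116 cells (Homo sapiens) for inhibition, read by sulforhodamine B assay, with a stated time of 48 h, tested at 50 uM (a lower number here means less inhibition of growth, a higher number more inhibition of growth at the concentration tested), the three values lie within the scatter of one another, so compound 1 stands level with compound 2 and compound 3. Compound 4 `COc1cc(/C=C/C(=O)/C=C/c2cccs2)ccc1OCc1cn(CCCCOc2cc(=O)oc3ccccc23)nn1` comes next: thiophen-2-yl in place of phenyl on a double-bonded chain carbon bound to a double-bonded chain carbon. For the measured compounds named here, the only measured step at this place is a number 2 percentage points higher from compound 2 to compound 3 (within the scatter), with 2-methoxyphenyl replacing thiophen-2-yl. It is not the same exchange, but it offers no sign of a large effect. No change beyond the scatter is therefore expected in this assay. The expected step is a number 2 percentage points lower from compound 1 to compound 4 (within the scatter). For compound 4 the estimated value is 32%, with a range of 23% to 41%.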

Compound 4, percent growth inhibition at one concentration: 41%
Compound 4: the middle estimate sits 9 percentage points below what was measured; low and high end bracket the measured number.
By their numbers in this assay, from the lowest: compounds 2, 3, 1 and 4 (each within the scatter of the next).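

In this assay the direct exchange of phenyl for thiophen-2-yl on a double-bonded chain carbon bound to a double-bonded chain carbon gives a number 7 percentage points higher from compound 1 to compound 4 (within the scatter) with the chain and the shared core unchanged. For the compounds shown here, this is the first matched reading of this exchange, and it shows that thiophen-2-yl is tolerated at this place. Nothing on hand explains the size of this step.

Going by these compounds, how a furan-2-yl ring, a pyridine ring or a phenyl ring bearing an amine would read at this place remains open. Also open, on these data alone, is whether the compounds separate across a range of concentrations, since a single concentration cannot show this.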